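This account rests on a few compounds, and the source may have more. Where it says the series, first, only, none or still open, it means among the compounds named here.

Working notes on the series. Among the measured compounds shown here, in an assay on HEK293 cells for displacement of a labelled ligand from 5-hydroxytryptamine receptor 7 (Rattus norvegicus) (a higher number here means a weaker inhibitor, a lower number a stronger inhibitor), compound 2 `O=C(CCCCCN1CCN(c2nc3ccccc3o2)CC1)NC1CCCc2ccccc21` gives 820 nM, the only number recorded so far. Compound 1 `COc1ccccc1N1CCN(CC(=O)NC2CCCc3c(OC)cccc32)CC1` is reported in this assay only as a limit, > 1000 nM, so the two values cannot be ordered against each other; the limit of > 1000 nM in this assay, at which 1 of the 2 values shown sits, marks that entry. Compound 3 `N#Cc1ccc(N2CCN(CCCCCC(=O)NC3CCCc4ccccc43)CC2)cc1` is not yet measured. It differs from compound 2 in one place: 4-cyanophenyl in place of 1,3-benzoxazol-2-yl on an amine nitrogen in a ring. For the measured compounds named here, no measured step covers this exchange, so the expected change from compound 2 to compound 3 is set at a 1.2-fold higher number from compound 2 to compound 3 (0.09 log units; within the scatter), modest and within the scatter or a little weaker. Compound 3 is estimated at 1000 nM, with a plausible range from 300 nM to 3000 nM.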

Compound 3, inhibition constant: 1400 nM
The estimate for compound 3 lay 1.4-fold (0.15 log units) below the measured number; the measured number falls inside the stated range.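

In this assay, among the compounds shown here, the exchange on an amine nitrogen in a ring gives the first readable step at this position: a 1.7-fold higher number from compound 2 to compound 3 (0.23 log units; within the scatter). This position therefore accepts 4-cyanophenyl in place of 1,3-benzoxazol-2-yl with no change beyond the scatter, although a one-ring group carrying a nitrile replaces a two-ring group. No recorded measurement bears on the cause of this step.

As far as these compounds go, how a carboxylic acid or a primary amine in place of the nitrile would read remains open. So does the effect of a shorter chain on the amide.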